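Lengthening the Amine Chain Beyond the Urea Series

A few compounds are considered here, and "the series" means these few. Any claim that something is new, unique, unknown or untested is made for them only; others in the source may bear on it.

compound 1 `CN(C)CCNc1nc(-c2ccc(NC(=O)Nc3ccc(F)cc3)cc2)nc2c(Cl)c(Cl)sc12` gives 1240 nM
compound 2 `CN(C)CCNc1nc(-c2ccc(NC(=O)Nc3ccc(Cl)cc3)cc2)nc2c(Cl)c(Cl)sc12` gives 870 nM
compound 3 `CN(C)CCNc1nc(-c2ccc(NC(=O)Nc3ccc(Cl)cc3Cl)cc2)nc2c(Cl)c(Cl)sc12` gives 3500 nM

These three numbers come from a functional assay on MDA-MB-231 cells (Homo sapiens) for cytotoxicity, read by MTT assay, with a stated time of 72 h; a higher number here means a weaker inhibitor, a lower number a stronger inhibitor. Compound 3 stands at the highest of them, that is, it is the weakest inhibitor of the three. Its distance from the others is beyond the scatter: a 2.8-fold higher number from compound 1 to compound 3 (0.45 log units; beyond the scatter) and a 4.0-fold higher number from compound 2 to compound 3 (0.60 log units; beyond the scatter). Between the other two the step is small, a 1.4-fold lower number from compound 1 to compound 2 (0.15 log units; within the scatter), so compound 1 and compound 2 cannot be ranked against each other.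

Compound 4 `CCN(CC)CCNc1nc(-c2ccc(NC(=O)Nc3ccc(Cl)cc3Cl)cc2)nc2c(Cl)c(Cl)sc12` is made from compound 3 by one change: diethylamino in place of dimethylamino on a saturated chain carbon, two bonds along the chain from a nitrogen on an aromatic ring. Going by the values given here, none of the measured steps touches this part of the molecule; all three alter the ring attached to the urea, and the amine on the chain stays the same throughout. Among the compounds with values here, there is therefore no measured step that bears on this change, and the expectation for this assay is a step no larger than the scatter, no change at the digits printed from compound 3 to compound 4 (within the scatter). Compound 4 is thus estimated at 3500 nM, with a range from 1400 nM to 9000 nM.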

Compound 4, half-maximal inhibitory concentration: 1920 nM
Estimate against measurement, compound 4: 1.8-fold (0.26 log units) above, within the range that was stated.
By their numbers in this assay, from the lowest: compounds 2, 1, 4 and 3 (each within the scatter of the next, the first and the last beyond it).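

Going by these compounds alone, the earlier compounds all carry dimethylamino, so only this step speaks to the amine at the end of the chain. In this assay, diethylamino in place of dimethylamino gives a 1.8-fold lower number from compound 3 to compound 4 (0.26 log units; within the scatter), which means that on the 2,4-dichlorophenyl urea, this position accepts diethylamino with no change that stands clear of the scatter. No data shown here bear on how either amine acts in these cells.

Diethylamino appears only with the 2,4-dichlorophenyl urea, so it remains open whether the same swap would read alike on the 4-fluorophenyl urea of compound 1 or the 4-chlorophenyl urea of compound 2. Also open, on these data alone, is how a ring amine such as pyrrolidine or morpholine, or a longer chain carrying the amine, would read at this place.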